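Phenylcyclopropyl in place of fluorobenzyl on the thiophene core

The source may report more compounds than this note shows. Statements on the series, on what has been measured and on what is new or still open speak of the compounds shown alone.

Compound 1 `N#Cc1cccc(-c2nc(N)c3cc(Cc4ccccc4)sc3n2)c1` gives 222 nM in a functional assay on CHO-K1 cells for antagonist activity at adenosine receptor A1 (Homo sapiens), read by a beta-galactosidase reporter and cAMP accumulation, with stated times of 15 min and 6 h; on this read-out lower numbers stand for stronger inhibition and higher numbers for weaker inhibition. Compound 2 `N#Cc1cccc(-c2nc(N)c3cc(Cc4ccccc4F)sc3n2)c1` gives < 16 nM in this assay, a limit of the assay rather than a number (the limit of < 16 nM in this assay, at which 1 of the 2 values shown sits). The step of an at least 13-fold lower number from compound 1 to compound 2 (1.14 log units; beyond the scatter) is the only measured one. Compound 3 `N#Cc1cccc(-c2nc(N)c3cc(C4(c5ccccc5)CC4)sc3n2)c1` differs from compound 2 by 1-phenylcyclopropyl in place of 2-fluorobenzyl on an aromatic carbon. That change also removes the fluorine that marked the measured step, so compound 2 is estimated to lose ground to compound 3 by an at least 3.7-fold higher number from compound 2 to compound 3 (0.57 log units; beyond the scatter). Compound 3 is therefore expected to give about 60 nM, within 10 nM to 400 nM.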

Compound 3, inhibition constant: > 610 nM
Compound 3 gave a limit, no number; the forecaster's own chance of this, stated with the estimate: 20%; at least 10-fold (1.00 log units) between middle value and limit.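

Replacing 2-fluorobenzyl with 1-phenylcyclopropyl on the aromatic carbon next to the ring sulfur gives an at least 38-fold higher number from compound 2 to compound 3 (1.58 log units; beyond the scatter), and replacing plain benzyl at the same place gives an at least 2.7-fold higher number from compound 1 to compound 3 (0.43 log units; beyond the scatter), so the loss is not only that of the fluorine. The value of compound 3 is a limit of the assay and not a number, which makes both steps minimum sizes: the limit of > 610 nM in this assay, at which 1 of the 3 values shown sits.

The compounds shown leave open whether 1-(2-fluorophenyl)cyclopropyl would regain anything over 1-phenylcyclopropyl. They also leave open whether 1-phenylethyl would behave like benzyl or like 1-phenylcyclopropyl.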